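The source may report more compounds than this note shows. Statements on the series, on what has been measured and on what is new or still open speak of the compounds shown alone.

Of the compounds shown here, two have been read so far in an ADME assay (liver) for metabolic stability, with Liver microsome (Rattus norvegicus) as the target, read by LC-MS, using microsomes and NADPH, with stated times of 5 min and 60 min, tested at 4 uM; on this read-out lower numbers stand for a less stable compound and higher numbers for a more stable compound. Compound 1 `CCCC(=O)c1ccc(OCCCCOc2cc(C(=O)O)ccc2OC)c(C)c1O` gives 1%, and compound 2 `Cc1ccc(C(=O)O)cc1OCCCCOc1ccc(C(=O)CC(C)C)c(O)c1C` gives 21%. Compound 2 therefore holds the higher of the two numbers, and the gap between them lies beyond the usual scatter of repeated measurements.

The next compound, compound 3 `COc1ccc(C(=O)O)cc1OCCCCOc1ccc(C(=O)CC(C)C)c(O)c1C`, departs from compound 2 in one place, with methoxy in place of methyl on an aromatic carbon, ortho to a large group and para to a carboxy group. The counted change is methoxy in place of methyl on an aromatic carbon.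

Among the measured compounds shown here, no measured pair shows this swap on its own, so the evidence is thin. For the measured compounds named here, the only pointer is that compound 1, which also carries methoxy, stands at 1% in this assay, yet one compound cannot isolate the effect of a single group. A moderate fall is expected, and the estimated change is a number 11 percentage points lower from compound 2 to compound 3 (beyond the scatter), close to the edge of the scatter. For compound 3 the expected value is 10%, with an estimated range from 2% to 24%.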

Compound 3, percent of the compound remaining: 5%
The estimate for compound 3 lay 5 percentage points above the measured number; low and high end bracket the measured number.
By their numbers in this assay, from the lowest: compounds 1 and 3 (each within the scatter of the next); then compound 2.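

In this assay, the swap at this aromatic carbon, ortho to a large group and para to a carboxy group, now has a measured pair of its own: methoxy in place of methyl gives a number 16 percentage points lower from compound 2 to compound 3 (beyond the scatter), so this position responds to the change, and the lower number goes with methoxy. The other end of the molecule reads differently, as methyl in place of hydrogen on a saturated chain carbon bound to two saturated chain carbons gives a number 4 percentage points higher from compound 1 to compound 3 (within the scatter), so with methoxy in place, this extra methyl shows no effect that stands clear of the scatter. Nothing shown explains why methoxy gives the lower number.

From the compounds shown here alone, it remains open how other groups would read at this aromatic carbon, such as a plain hydrogen, a chlorine or an ethoxy, and so whether the step follows from the added oxygen or from the larger group. Also open, going by these compounds, is whether the extra methyl on the chain would still show no clear effect with methyl rather than methoxy on the aromatic carbon.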